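Amide aryl variation in a thiazolo-quinazoline cytotoxicity series

The source may hold more compounds than are shown below. What is called first, only, known or untested is meant among the compounds shown, and "the series" means these compounds.

Measured so far:
compound 1, `COc1cc2c(Nc3nc4ccc(C(=O)Nc5c(C)cc(C)cc5C)cc4s3)ncnc2cc1OCCCN1CCC(C)CC1`: 5600 nM
compound 2, `CCN(CC)CCCOc1cc2ncnc(Nc3nc4ccc(C(=O)Nc5c(C)cccc5C)cc4s3)c2cc1OC`: 23700 nM
compound 3, `CCN(CC)CCCOc1cc2ncnc(Nc3nc4ccc(C(=O)Nc5c(C)cccc5Cl)cc4s3)c2cc1OC`: 7300 nM

All values come from a functional assay on U-937 cells (Homo sapiens) for cytotoxicity, read by WST assay, with a stated time of 72 h; on this read-out lower numbers stand for stronger inhibition and higher numbers for weaker inhibition. Compound 3 stands second highest of the three numbers; compound 1 is within the scatter of it, while compound 2 lies beyond. Among the measured compounds shown here, the one single-point step in hand is a 3.2-fold lower number from compound 2 to compound 3 (0.51 log units; beyond the scatter).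

Compound 4, `CCN(CC)CCCOc1cc2ncnc(Nc3nc4ccc(C(=O)Nc5c(C)cc(C)cc5C)cc4s3)c2cc1OC`, is not yet measured in this assay. It differs from compound 3 by 2,4,6-trimethylphenyl in place of 2-chloro-6-methylphenyl on an amide-type nitrogen. This reverses the chloro-for-methyl exchange seen in a 3.2-fold lower number from compound 2 to compound 3 (0.51 log units; beyond the scatter) and at the same time adds a third methyl; compound 4 therefore shares its amide aryl group with compound 1 and its side chain with compound 2 and compound 3. For the measured compounds named here, no measured step isolates the added methyl, so the two numbers of compound 1 and compound 2 frame the expectation only loosely. On balance a moderate rise in number is expected for compound 4, giving an estimated step of a 1.5-fold higher number from compound 3 to compound 4 (0.18 log units; within the scatter) in this assay. Compound 4 is therefore estimated at 11000 nM, with a range from 4500 nM to 28000 nM.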

Compound 4, half-maximal inhibitory concentration: 4300 nM
Beside the measured number, compound 4's estimate is 2.6-fold (0.41 log units) above it; measured number below the stated range.
By their numbers in this assay, from the lowest: compounds 4, 1 and 3 (each within the scatter of the next); then compound 2.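

In this assay, among the compounds shown here, adding methyl in place of hydrogen on an aromatic carbon of the amide aryl group gives a 5.5-fold lower number from compound 2 to compound 4 (0.74 log units; beyond the scatter), so this amide aryl group responds to a single added methyl, which no earlier step could show. Compound 4 cannot be separated from compound 3, with a 1.7-fold lower number from compound 3 to compound 4 (0.23 log units; within the scatter), or from compound 1, with a 1.3-fold lower number from compound 1 to compound 4 (0.11 log units; within the scatter), so neither 2,4,6-trimethylphenyl in place of 2-chloro-6-methylphenyl nor diethylamino in place of 4-methylpiperidin-1-yl moves the number beyond the scatter, and only compound 2 stands apart. No measurement at hand accounts for these steps.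

Still open, going by these compounds, is whether chloro or methoxy on the aromatic carbon that takes the added methyl would match methyl. Also open is whether a morpholin-4-yl group on the chain would match the two amines shown.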